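The compounds below may be only part of what the source reports. "The series", "measured", "known", "first", "only" and "open" are said of these compounds alone.

Three members of the series have so far been measured in an assay on HEK293 cells for inhibition of Steryl-sulfatase (Homo sapiens), tested at 0.1 uM; a higher number here means a stronger effect of the compound at the concentration tested, a lower number a weaker effect. Compound 1 `CCN(Cc1cccnc1)c1ccc(C(=O)N2CCc3ccc(OS(N)(=O)=O)cc3C2)cc1` gives 35.7%. Compound 2 `CCN(Cc1cccc(Br)c1)c1cccc(C(=O)N2CCc3ccc(OS(N)(=O)=O)cc3C2)c1` gives 20.9%. Compound 3 `NS(=O)(=O)Oc1ccc2c(c1)CN(C(=O)c1ccc(N3CCN(c4ncccn4)CC3)cc1)CC2` gives 14.7%. Compound 2 thus holds the second highest of the three numbers: its nearest neighbour is compound 3, whose number lies within the usual scatter of it, and the furthest is compound 1, whose number lies beyond the scatter above it. Within the data shown here, no two measured compounds differ in a single place, so no measured step is at hand to guide the next change.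

Compound 4 `CN(CCCN1CCCCC1)c1cccc(C(=O)N2CCc3ccc(OS(N)(=O)=O)cc3C2)c1` is not yet measured. It is derived from compound 2 by the change (methyl(3-(piperidin-1-yl)propyl)amino in place of (3-bromobenzyl)(ethyl)amino on an aromatic carbon), made on an aromatic carbon meta to a large group. Among the measured compounds shown here, no measured pair isolates a change of this kind, so no direction can be read from the data. The step expected in this assay, a number 2.9 percentage points lower from compound 2 to compound 4 (within the scatter), is estimated to stay within the scatter, with at most a slight tendency downward. Compound 4 is accordingly estimated at 18% in this assay, with an expected range from 5% to 34%.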

Compound 4, a percentage reported as inhibition, at one concentration (the size of the read-out at that concentration, not a potency): 24.1%
Compound 4: the middle estimate sits 6.1 percentage points below what was measured, within the range that was stated.
By their numbers in this assay, from the lowest: compounds 3, 2 and 4 (each within the scatter of the next); then compound 1.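

Among these compounds, the first measured step at this position shows that, in this assay, replacing (3-bromobenzyl)(ethyl)amino with methyl(3-(piperidin-1-yl)propyl)amino gives a number 3.2 percentage points higher from compound 2 to compound 4 (within the scatter), so the read-out does not separate the two groups at this aromatic carbon, meta to a large group. The exchange is a large one in kind: a six-membered aromatic ring of carbon only and the bromine leave, while a six-membered non-aromatic ring with 1 hetero atom and a second nitrogen enter, at the same count of 11 heavy atoms, and the number still stays within the scatter. No measured information on the compounds explains this outcome.

Open, on these data alone, is whether a morpholine ring in place of the piperidine, or an ethyl chain in place of the propyl chain, would keep the number within the scatter of compound 4. Also open is what each part of the exchange contributes: the ring, the bromine and the ethyl group all leave in a single step, and the compounds shown hold no pair that separates them.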